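Aryl variation at the saturated ring carbon: Ehrlich cell series

The compounds below may be only part of what the source reports. "The series", "measured", "known", "first", "only" and "open" are said of these compounds alone.

Measured so far:
compound 1 `COc1cc(CC2C(C#N)=C(N)N(c3ccc(S(N)(=O)=O)cc3)C3=C2C(=O)CCC3)ccc1O`: 0%
compound 2 `N#CC1=C(N)N(c2ccc(S(N)(=O)=O)cc2)C2=C(C(=O)CCC2)C1c1ccc(Cl)cc1Cl`: 40%
compound 3 `COc1ccc(C2C(C#N)=C(N)N(c3ccc(S(N)(=O)=O)cc3)C3=C2C(=O)CCC3)c2ccccc12`: 10%

All three share one core and differ only in the group on a saturated ring carbon. In a functional assay on Ehrlich cells (Mus musculus) for antiproliferative activity, read by trypan blue exclusion, with a stated time of 2 h, tested at 10 ug/mL (a lower number here means a weaker effect, a higher number a stronger effect of the compound at the concentration tested), compound 3 stands second highest of the three numbers; its nearest neighbour is compound 1, a gap within the scatter, and its furthest is compound 2. The steps recorded are a number 40 percentage points higher from compound 1 to compound 2 (beyond the scatter), a number 10 percentage points higher from compound 1 to compound 3 (within the scatter) and a number 30 percentage points lower from compound 2 to compound 3 (beyond the scatter): only the 2,4-dichlorophenyl group lifts the read-out clearly, while the 4-hydroxy-3-methoxybenzyl and 4-methoxynaphthalen-1-yl groups sit together near the bottom.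

Compound 4 `N#CC1=C(N)N(c2ccc(S(N)(=O)=O)cc2)C2=C(C(=O)CCC2)C1c1cccs1` is not yet measured. Its change from compound 3 is thiophen-2-yl in place of 4-methoxynaphthalen-1-yl on a saturated ring carbon. Among the measured compounds shown here, no measured step involves thiophen-2-yl, so the bearing of the three steps is indirect: the two aryl groups that are not 2,4-dichlorophenyl both give low numbers, and only one of the three substitutions moved the read-out beyond the scatter. Compound 4 is therefore expected near the level of compound 3, a step of a number 5 percentage points higher from compound 3 to compound 4 (within the scatter) that is not expected to exceed the scatter. For compound 4 the estimate is 15% in this assay, with a range from 0% to 40%.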

Compound 4, a percentage reported as activity, at one concentration (the size of the read-out at that concentration, not a potency): 70%
Estimate against measurement, compound 4: 55 percentage points below; measured number outside the range, above it.
By their numbers in this assay, from the lowest: compounds 1 and 3 (each within the scatter of the next); then compound 2; then compound 4.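

In this assay, the thiophen-2-yl group on the saturated ring carbon gives the highest read-out of the series, with a number 60 percentage points higher from compound 3 to compound 4 (beyond the scatter), a number 30 percentage points higher from compound 2 to compound 4 (beyond the scatter) and a number 70 percentage points higher from compound 1 to compound 4 (beyond the scatter). The position can therefore carry a much larger effect than the first three compounds showed, and the 2,4-dichlorophenyl group no longer marks the top of the range. Nothing available explains why this exchange raises the read-out.

The compounds shown leave open whether the rise follows the sulfur atom, the five-membered ring or the fewer heavy atoms of thiophen-2-yl, as these all change together from compound 3 to compound 4. Going by these compounds, a furan-2-yl or plain phenyl group on the same carbon would help separate them, while potency remains open, as each read-out comes from a single concentration.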